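The source may report more compounds than this note shows. Statements on the series, on what has been measured and on what is new or still open speak of the compounds shown alone.

In a functional assay on DU-145 cells (Homo sapiens) for inhibition, read by trypan blue exclusion, with a stated time of 96 h (on this read-out lower numbers stand for stronger inhibition of growth and higher numbers for weaker inhibition of growth), the measured compounds stand as follows:
- compound 1 `O=C(O)c1ccc(C(=O)/C(=C\c2ccc(Cl)c([N+](=O)[O-])c2)SCc2ccc(Br)cc2)cc1` gives 500 nM
- compound 2 `O=C(O)c1ccc(C(=O)/C(=C\c2ccc(Br)c([N+](=O)[O-])c2)SCc2ccc(F)cc2)cc1` gives 1000 nM

Compound 2 at 1000 nM and compound 1 at 500 nM lie within the usual scatter of each other, so these two numbers do not separate them.

Compound 3 `O=C(O)c1ccc(C(=O)/C(=C\c2ccc(Br)c([N+](=O)[O-])c2)SCc2ccc(Br)cc2)cc1` comes from compound 2 by a single change, bromo in place of fluoro on an aromatic carbon in short: bromo in place of fluoro on an aromatic carbon, so that 4-fluorobenzyl becomes 4-bromobenzyl. Going by the values given here, no two measured compounds differ in one place only, so no measured step shows what this swap does on its own in this assay of this series. Among the compounds with values here, with compound 1 at 500 nM and compound 2 at 1000 nM as the only guides, no step beyond the scatter is expected. The estimate is a 1.7-fold lower number from compound 2 to compound 3 (0.22 log units; within the scatter) and so stays within the scatter. Compound 3 is expected at 600 nM with an estimated range of 250 nM to 1400 nM as its likely span.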

Compound 3, concentration for 50% growth inhibition in the DU-145 assay: 1000 nM
For compound 3 the middle estimate is 1.7-fold (0.22 log units) below the measured one, and the stated range covers the measured number.
By their numbers in the DU-145 assay, from the lowest: compounds 1, 2 and 3 (each within the scatter of the next).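

Going by these compounds alone, for the first time, the DU-145 assay offers pairs of compounds that differ in one place only. Changing 4-fluorobenzyl to 4-bromobenzyl gives no change at the digits printed from compound 2 to compound 3 (within the scatter), so this read-out does not tell fluoro and bromo apart at this position. At another aromatic carbon, bromo in place of chloro gives a 2.0-fold higher number from compound 1 to compound 3 (0.30 log units; within the scatter), so that halogen swap does not separate its two compounds either.

On these data alone, whether a group other than a halogen at the position of the fluoro, such as an amine or a methoxy group, would shift the number beyond the scatter remains open. In a physicochemical assay for solubility (on this read-out lower numbers stand for lower solubility and higher numbers for higher solubility), compound 2 gives < 1000 ug/mL and this is a limit of the assay and not a number. In the physicochemical assay compound 3 gives < 1000 ug/mL and this too is a limit of the assay and not a number. In the physicochemical assay the step from compound 2 to compound 3 cannot be read, because both compounds give a limit and not a number: the limit of < 1000 ug/mL in the physicochemical assay, at which 2 of the 2 values shown sit.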